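The source may report more compounds than this note shows. Statements on the series, on what has been measured and on what is new or still open speak of the compounds shown alone.

Measured compounds:
compound 1 `COC(=O)c1cc(-c2cccc(NC(=O)c3ccc(/C=C/C(=O)c4ccc(C)cc4)cc3)c2)on1`: > 80 ug/mL
compound 2 `CCOC(=O)c1nnn(-c2cccc(NC(=O)c3ccc(/C=C/C(=O)c4ccc(Cl)cc4)cc3)c2)c1C`: "not determined" (no result reported)

In an ADME assay on Vero cells (Chlorocebus sabaeus) for cytotoxicity, read by MTT assay, with a stated time of 72 h (a lower number here means that less compound is tolerated, a higher number that more compound is tolerated), compound 1 gives > 80 ug/mL. This is a limit of the assay and not a number; compound 1 sits at the limit of > 80 ug/mL in this assay, at which 1 of the 2 values shown sits. Within the data shown here, for compound 2 the entry in this assay reads "not determined" (no result reported), so no single value exists for it and no step between measured compounds can be drawn from these two entries. Where compound 1 stands is therefore known only as a limit, with the second entry giving no number beside it.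

Compound 3 `COC(=O)c1cc(-c2cccc(NC(=O)c3ccc(/C=C/C(=O)c4ccc(Cl)cc4Cl)cc3)c2)on1` differs from compound 1 by 2,4-dichlorophenyl in place of 4-methylphenyl on a carbonyl carbon, the change sitting on a carbonyl carbon whose other neighbour is a double-bonded chain carbon. Because compound 1 stands at the limit of > 80 ug/mL in this assay, at which 1 of the 2 values shown sits, compound 3 is expected to stay near that limit in this assay. The expected step is an at least 1.1-fold lower number from compound 1 to compound 3 (0.05 log units; that floor lies within the scatter), small and, if anything, toward less compound tolerated, and not clearly beyond the usual scatter. Compound 3 is therefore estimated at 70 ug/mL, with a range from 30 ug/mL to 100 ug/mL, and a fair chance that only a limit is reported again.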

Compound 3, half-maximal cytotoxic concentration: > 40 ug/mL
Compound 3 gave a limit, no number; the forecaster's own chance of this, stated with the estimate: 55%; the middle value is on the limit's open side.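

In this assay compound 3 gives > 40 ug/mL, which is a limit of the assay and not a number. Compound 1 gives > 80 ug/mL, which is also a limit. Among these compounds, no step from compound 1 to compound 3 can be read from these two limits. The compounds shown leave open what concentration of either compound is actually tolerated, and whether 2,4-dichlorophenyl in place of 4-methylphenyl on a carbonyl carbon shifts it at all.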